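Amide variation on the shared core: thiophene for cyclopropyl

The source may hold more compounds than are shown below. What is called first, only, known or untested is meant among the compounds shown, and "the series" means these compounds.

Measured so far:
compound 1 `CC(C)CC(=O)N1CCc2cc(CNC(=O)C3CC3)ccc21` — 35%
compound 2 `CCC(=O)N1CCc2cc(CNC(=O)c3ccnn3C)ccc21` — 14%
compound 3 `CC(C)C(=O)N1CCc2cc(CNC(=O)c3ccccc3)ccc21` — 100%

In an assay on HEK293 cells for inhibition of Indoleamine 2,3-dioxygenase 1 (Homo sapiens), tested at 10 uM (a lower number here means less inhibition, a higher number more inhibition at the concentration tested (going by the name of the read-out)), compound 1 gives 35%, the second highest of the three numbers. Compound 2 sits lower, by a gap beyond the usual scatter, and compound 3 sits higher, again beyond the scatter. Compound 4 `CC(C)CC(=O)N1CCc2cc(CNC(=O)c3cccs3)ccc21` is not yet measured; against compound 1 it shows (thiophen-2-yl in place of cyclopropyl on a carbonyl carbon). Going by the values given here, no measured pair shows this change, so its size is open. A step upward beyond the scatter is expected, because compound 3 gives 100%. The expected step is a number 25 percentage points higher from compound 1 to compound 4 (beyond the scatter). For compound 4 the estimate is 60%, within a range from 30% to 95%.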

Compound 4, a percentage reported as inhibition, at one concentration (the size of the read-out at that concentration, not a potency): 100%
The estimate for compound 4 lay 40 percentage points below the measured number; the whole stated range lies below it.
By their numbers in this assay, from the lowest: compound 2; then compound 1; then compounds 3 and 4 (each within the scatter of the next).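

In this assay, going by these compounds alone, thiophen-2-yl in place of cyclopropyl on a carbonyl carbon gives a number 65 percentage points higher from compound 1 to compound 4 (beyond the scatter), the first step that can be read at a single place. This amide position alone can therefore move the read-out by a large amount with the rest of compound 1 unchanged. Compound 4 at 100% is a reading at one concentration, not a potency.

Open, from the compounds shown here alone, is whether furan-2-yl, pyridin-2-yl or a longer alkyl chain on this carbonyl carbon would match compound 4. No measurement at hand gives a reason for the step.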